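Varying the Amide Aryl Group on a Shared Core

A few compounds are considered here, and "the series" means these few. Any claim that something is new, unique, unknown or untested is made for them only; others in the source may bear on it.

Compound 1 `COc1ccc(C(=O)Nc2cccc(-c3oc4cc(-c5ccc(F)cc5)ccc4c(=O)c3O)c2)cc1`: 6250 nM
Compound 2 `Cc1cc(C(=O)Nc2cccc(-c3oc4cc(-c5ccc(F)cc5)ccc4c(=O)c3O)c2)ccc1F`: 7710 nM

Both measured compounds share a core and differ only in the aryl group attached to the amide carbonyl carbon. In a functional assay on MCF7 cells (Homo sapiens) for antiproliferative activity, read by CCK-8 assay, with a stated time of 72 h (a higher number here means a weaker inhibitor, a lower number a stronger inhibitor), compound 1 gives 6250 nM, and in this assay compound 2 gives 7710 nM. Going by the values given here, the one measured step, a 1.2-fold higher number from compound 1 to compound 2 (0.09 log units; within the scatter), lies within the scatter, so compound 2 and compound 1 cannot be told apart on these numbers; compound 2 has no nearer neighbour than compound 1.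

Compound 3 `COc1cc(OC)cc(C(=O)Nc2cccc(-c3oc4cc(-c5ccc(F)cc5)ccc4c(=O)c3O)c2)c1` differs from compound 2 by 3,5-dimethoxyphenyl in place of 4-fluoro-3-methylphenyl on a carbonyl carbon. Among the compounds with values here, this is the same kind of change as the one measured step, an exchange of the aryl group on the carbonyl carbon whose other neighbour is the amide-type nitrogen. That step, a 1.2-fold higher number from compound 1 to compound 2 (0.09 log units; within the scatter), did not move the number beyond the scatter. Within the data shown here, with only that step to go on, the expected step of a 1.1-fold lower number from compound 2 to compound 3 (0.04 log units; within the scatter) is none beyond the scatter, in no particular direction. Compound 3 is therefore estimated to give 7000 nM in this assay, with a range from 3000 nM to 16000 nM.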

Compound 3, half-maximal inhibitory concentration: 3470 nM
Compound 3: middle estimate off by 2.0-fold (0.30 log units), on the high side; measured number inside the range.
By their numbers in this assay, from the lowest: compounds 3, 1 and 2 (each within the scatter of the next, the first and the last beyond it).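

In this assay the aryl group on the carbonyl carbon whose other neighbour is the amide-type nitrogen can move the number beyond the scatter: 3,5-dimethoxyphenyl in place of 4-fluoro-3-methylphenyl gives a 2.2-fold lower number from compound 2 to compound 3 (0.35 log units; beyond the scatter) as a modest step, whereas the earlier exchange at this place stayed within the scatter. 3,5-Dimethoxyphenyl in place of 4-methoxyphenyl gives a 1.8-fold lower number from compound 1 to compound 3 (0.26 log units; within the scatter) and also stays within the scatter, so compound 3 cannot be told apart from compound 1, and only compound 2 and compound 3 separate. The entering group counts two hydrogen-bond acceptors and the leaving group none, but no evidence is available to connect that count or any other feature with the step.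

The exchange between compound 2 and compound 3 removes the fluorine and the methyl group and adds two methoxy groups at once, so these compounds leave open which of those differences goes with the step. They also leave open how an aryl group carrying an amine or a carboxylic acid, or a longer chain on the same carbonyl carbon, would read in this assay on the shared core.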